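The compounds below may be only part of what the source reports. "The series", "measured", "known", "first", "only" and "open" are said of these compounds alone.

Compound 1 `CCN(C(=O)CN(c1cc(N(C)C)ccc1Cl)S(=O)(=O)c1ccc(OC)c(OC)c1)c1cccc(C)n1`: 5 nM
Compound 2 `CCN(CC)C(=O)CN(c1cc(N(CC)CC)ccc1Cl)S(=O)(=O)c1ccc(OC)c(OC)c1`: 2410 nM
Compound 3 `CCN(CC)C(=O)CN(c1ccc(C)cc1)S(=O)(=O)c1cccc(C)c1`: 60 nM

All three numbers come from a functional assay on CHO cells for inhibition of Orexin receptor type 2 (Homo sapiens), read by FLIPR and calcium flux; on this read-out higher numbers stand for weaker inhibition and lower numbers for stronger inhibition. Compound 3 stands second highest of the three: compound 1 lies lower and compound 2 higher, and both gaps are beyond the usual scatter. Compound 4 `CCN(CC)C(=O)CN(c1ccc(C)cc1)S(=O)(=O)c1ccc(OC)cc1` differs from compound 3 in a single place: 4-methoxyphenyl in place of 3-methylphenyl on a sulfonyl sulfur. Going by the values given here, no measured pair shows this change on its own, so its size cannot be read from the data; compounds 1 and 2 differ from compound 3 in several places at once and give no clean guide. For compound 4 a step of modest size is expected, toward stronger inhibition if anything, as a 1.5-fold lower number from compound 3 to compound 4 (0.18 log units; within the scatter). Compound 4 is estimated at 40 nM, with a range from 10 nM to 200 nM.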

Compound 4, half-maximal inhibitory concentration: 661 nM
For compound 4 the middle estimate is 17-fold (1.22 log units) below the measured one; the whole stated range lies below it.
By their numbers in this assay, from the lowest: compound 1; then compound 3; then compound 4; then compound 2.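

In this assay, going by these compounds alone, the sulfonyl sulfur position proves sensitive to its aryl group: 4-methoxyphenyl in place of 3-methylphenyl gives an 11-fold higher number from compound 3 to compound 4 (1.04 log units; beyond the scatter) and is the first single-place step. The step is large, so this position cannot be treated as tolerant of any aryl group. Nothing at hand explains the loss.

The change swaps the substituent and its ring position together, so the two remain unseparated. As far as these compounds go, whether 3-methoxyphenyl, 4-methylphenyl or a ring bearing a nitrile would hold the inhibition of compound 3 stays open.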